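The compounds below may be only part of what the source reports. "The series", "measured", "known", "first", "only" and "open" are said of these compounds alone.

Measured in a functional assay on ileum (Cavia porcellus) for antagonist activity, with a stated time of 30 s; a lower number here means a stronger inhibitor, a higher number a weaker inhibitor:
Compound 1 `CCCc1ccccc1OCC(O)COc1ccc2c(=O)cc(C(=O)O)oc2c1CCC` gives 0.044 ug/mL
Compound 2 `C=CCc1ccccc1OCC(O)COc1ccc2c(=O)cc(C(=O)O)oc2c1` gives 1.8 ug/mL
Compound 3 `CCCc1c(OCC(O)COc2ccc3c(=O)cc(C(=O)O)oc3c2CCC)ccc(C(C)=O)c1OC` gives 45 ug/mL

Compound 3 has the highest of these numbers, so it is the weakest inhibitor of the three, and its gaps to both others lie beyond the scatter. Compound 4 `CCCc1cc(C(C)=O)ccc1OCC(O)COc1ccc2c(=O)cc(C(=O)O)oc2c1CCC` has hydrogen in place of methoxy on an aromatic carbon of compound 3 (hydrogen in place of methoxy on an aromatic carbon). Among the compounds with values here, no measured pair differs in just one place, so this step has no direct precedent. Compound 1 (0.044 ug/mL) shows how far down the numbers reach, and a move to a lower number, beyond the scatter, is expected in this assay. The expected change is the estimated step (a 30-fold lower number from compound 3 to compound 4 (1.48 log units; beyond the scatter)). Compound 4 is estimated at 1.5 ug/mL, with an expected range from 0.15 ug/mL to 15 ug/mL.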

Compound 4, half-maximal inhibitory concentration: 0.15 ug/mL
Estimate against measurement, compound 4: 10-fold (1.00 log units) above, within the range that was stated.
By their numbers in this assay, from the lowest: compound 1; then compound 4; then compound 2; then compound 3.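

Measured in this assay, the methoxy group on this aromatic carbon carries a heavy penalty: hydrogen in its place gives a 300-fold lower number from compound 3 to compound 4 (2.48 log units; beyond the scatter) and the step is large. The acetyl group costs less, with acetyl in place of hydrogen giving a 3.4-fold higher number from compound 1 to compound 4 (0.53 log units; beyond the scatter) and only a modest step. Nothing available explains why the methoxy group weighs so heavily here. On these data alone, whether any group at this position would do the same remains open: a hydroxyl group or a longer chain such as ethoxy would help to show this.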